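The source may report more compounds than this note shows. Statements on the series, on what has been measured and on what is new or still open speak of the compounds shown alone.

Working notes on the bile acid receptor series.

Three compounds of this series carry a shared core and differ mainly in the substituent on the aromatic nitrogen of the five-membered aromatic ring. Compound 1 `CCC(CC)n1c(-c2ccc(OCc3c(-c4c(Cl)cccc4Cl)noc3C(C)C)cc2F)nc2ccc(C(=O)O)cc21` gives 1.3 nM in an assay on Huh-7 cells for agonist activity at Bile acid receptor (Homo sapiens), read by a luciferase reporter; on this read-out lower numbers stand for an effect already at smaller amounts and higher numbers for an effect only at larger amounts of compound. Compound 2 `CCn1c(-c2ccc(OCc3c(-c4c(Cl)cccc4Cl)noc3C(C)C)cc2)nc2ccc(C(=O)O)cc21` gives 2.31 nM in this assay. Compound 3 `CC(C)c1onc(-c2c(Cl)cccc2Cl)c1COc1ccc(-c2nc3ccc(C(=O)O)cc3n2CC2CCCCC2)c(Cl)c1` gives 7.6 nM in this assay. Among these three numbers compound 2 stands second highest; its value and that of compound 1 lie within the scatter of each other, while its gap to compound 3 lies beyond it.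

Compound 4 `CC(C)c1onc(-c2c(Cl)cccc2Cl)c1COc1ccc(-c2nc3ccc(C(=O)O)cc3n2C2CCCCC2)cc1` has not been measured yet. It differs from compound 2 as follows: cyclohexyl in place of ethyl on an aromatic nitrogen. Among the compounds with values here, no step between measured compounds covers this exact change, so the expectation rests on what the three measured compounds show. The branched substituent of compound 1 and the ring-bearing substituent of compound 3 together frame the range in which a cyclohexyl on the aromatic nitrogen is expected to fall. The step of a 1.2-fold lower number from compound 2 to compound 4 (0.06 log units; within the scatter) is expected to stay within the scatter, with no clear direction. Compound 4 is therefore expected to give about 2 nM in this assay, with a range from 0.7 nM to 6 nM.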

Compound 4, half-maximal effective concentration: 4.21 nM
Beside the measured number, compound 4's estimate is 2.1-fold (0.32 log units) below it; measured number inside the range.
By their numbers in this assay, from the lowest: compounds 1, 2, 4 and 3 (each within the scatter of the next, the first and the last beyond it).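

Within the data shown here, replacing ethyl with cyclohexyl on the aromatic nitrogen gives a 1.8-fold higher number from compound 2 to compound 4 (0.26 log units; within the scatter) in this assay, the first reading of this position with the rest of the structure held constant. The earlier compounds shown here could only frame this position, since they differ from one another in more than one place; this pair shows that a six-membered non-aromatic ring of carbon only, with 6 heavy atoms in place of 2, can stand here without a step that can be told from the scatter. No accompanying measurement bears on this result.

On these data alone, it remains open whether this position would read the same with a phenyl ring set directly on the aromatic nitrogen, or with a chain ending in an amine or a hydroxyl group in place of the carbon-only groups seen so far. Also open, as far as these compounds go, is whether cyclohexyl in place of ethyl would give a similar step on a core carrying the fluorine of compound 1 or the chlorine of compound 3.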